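Substituent swap on the shared core: compound 2 to compound 4

The source may hold more compounds than are shown below. What is called first, only, known or untested is meant among the compounds shown, and "the series" means these compounds.

Three members of the series have been measured in a functional assay on CHO cells for agonist activity at adenosine receptor A1 (Homo sapiens), read by fluorescence and ERK phosphorylation, with stated times of 30 min and 1.5 h, tested at 10 uM; on this read-out higher numbers stand for a stronger effect at the one concentration tested and lower numbers for a weaker effect. Compound 1 `Nc1scc(-c2cccc(C(F)(F)F)c2)c1C(=O)c1ccccc1` gives 59%, compound 2 `Nc1scc(-c2cccc(F)c2)c1C(=O)c1ccccc1` gives 52%, and compound 3 `Nc1scc(-c2ccc(I)cc2)c1C(=O)c1ccccc1` gives 50%. Compound 2 sits within the scatter of both others: a number 7 percentage points lower from compound 1 to compound 2 (within the scatter) and a number 2 percentage points lower from compound 2 to compound 3 (within the scatter). The next member, compound 4 `Nc1scc(-c2cccc([N+](=O)[O-])c2)c1C(=O)c1ccccc1`, differs from compound 2 by nitro in place of fluoro on an aromatic carbon. Both measured steps bear on this change, since each alters the same six-membered ring of carbon only on the shared core, and neither moved the read-out beyond the scatter. No step beyond the scatter is therefore expected in this assay, no change at the digits printed from compound 2 to compound 4 (within the scatter). Compound 4 is estimated at 52%, with a range from 36% to 68%.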

Compound 4, a percentage reported as activity, at one concentration (the size of the read-out at that concentration, not a potency): 50%
Beside the measured number, compound 4's estimate is 2 percentage points above it; the range from low to high includes it.
By their numbers in this assay, from the lowest: compounds 3, 4, 2 and 1 (each within the scatter of the next).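

In this assay, the place meta to a large group has now carried fluoro, trifluoromethyl and nitro, and a number 2 percentage points lower from compound 2 to compound 4 (within the scatter) and a number 9 percentage points lower from compound 1 to compound 4 (within the scatter) do not separate the three groups. Nitro enters with hydrogen-bond acceptors that fluoro lacks, and this change to the substituent still gives no step beyond the scatter at this place. Nothing available gives a cause for this flat result. Open, going by these compounds, is whether an amine or a carboxylic acid at this place would give a step beyond the scatter. Also open, on these data alone, is whether nitro would read the same at another place on this ring.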